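The source may report more compounds than this note shows. Statements on the series, on what has been measured and on what is new or still open speak of the compounds shown alone.

Measured in a functional assay on DU-145 cells (Homo sapiens) for inhibition, read by trypan blue exclusion, with a stated time of 96 h; on this read-out lower numbers stand for stronger inhibition of growth and higher numbers for weaker inhibition of growth:
- compound 1 `O=C(O)c1ccc(C(=O)/C(=C\c2ccc(O)c([N+](=O)[O-])c2)SCc2ccc(Br)cc2)cc1` gives 50000 nM
- compound 2 `O=C(O)c1ccc(C(=O)/C(=C\c2ccc([N+](=O)[O-])c(O)c2)SCc2ccc(Br)cc2)cc1` gives 10000 nM
- compound 3 `CN(C)c1ccc(/C=C(/SCc2ccc(Br)cc2)C(=O)c2ccc(C(=O)O)cc2)cc1` gives 50000 nM

Compound 3 stands level with compound 1 at the digits reported, and compound 2 is the one that stands apart, with a 5.0-fold higher number from compound 2 to compound 3 (0.70 log units; beyond the scatter).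

The next change leads to compound 4 `CSc1ccc(/C=C(/SCc2ccc(Br)cc2)C(=O)c2ccc(C(=O)O)cc2)cc1`, with methylsulfanyl in place of dimethylamino on an aromatic carbon, para to a large group: methylsulfanyl in place of dimethylamino on an aromatic carbon.

Among the compounds with values here, no measured step makes this exact exchange. The closest evidence comes from exchanges of the whole substituted phenyl group at the same place. One of these gave no change at the digits printed from compound 1 to compound 3 (within the scatter). The other two, both involving compound 2, were modest: a 5.0-fold lower number from compound 1 to compound 2 (0.70 log units; beyond the scatter) and a 5.0-fold higher number from compound 2 to compound 3 (0.70 log units; beyond the scatter). With so few compounds, this gives only weak guidance, and no step beyond the scatter is expected in this assay.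

The expected step is a 1.3-fold lower number from compound 3 to compound 4 (0.10 log units; within the scatter).

For compound 4 the estimated value is 40000 nM, with an expected range of 10000 nM to 90000 nM.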

Compound 4, concentration for 50% growth inhibition: 10000 nM
Compound 4: the middle estimate sits 4.0-fold (0.60 log units) above what was measured; measured number inside the range.
By their numbers in this assay, from the lowest: compounds 2 and 4 (each within the scatter of the next); then compounds 1 and 3 (each within the scatter of the next).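

Within the data shown here, exchanging dimethylamino for methylsulfanyl on this aromatic carbon, para to a large group, is the first change of a single substituent at this position, and it gives a step beyond the scatter in this assay (a 5.0-fold lower number from compound 3 to compound 4 (0.70 log units; beyond the scatter)). The 3-hydroxy-4-nitrophenyl group of compound 2 therefore no longer stands alone, since 4-(methylsulfanyl)phenyl reaches the same level (no change at the digits printed from compound 2 to compound 4 (within the scatter)) without a nitro or hydroxy group, and it also separates from 4-hydroxy-3-nitrophenyl (a 5.0-fold lower number from compound 1 to compound 4 (0.70 log units; beyond the scatter)). Nothing available bears on the reason for these steps.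

Open, going by these compounds, is whether methoxy or the longer ethylsulfanyl chain on this aromatic carbon would sit with compound 4 or with compound 3. Also open, on these data alone, is whether the level of compound 4 would hold with a primary amide in place of the carboxylic acid.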